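A few compounds are considered here, and "the series" means these few. Any claim that something is new, unique, unknown or untested is made for them only; others in the source may bear on it.

For the measured compounds named here, compound 2 `O=S(=O)(c1cc(Cl)cc(Cl)c1)c1cnc2cc(F)ccc2c1-c1cccc(F)c1` holds the lower of the two numbers so far in an ADME assay on microsomes from liver (Homo sapiens) for metabolic stability, tested at 2.5 uM (a higher number here means faster removal of the compound, a lower number slower removal), where compound 2 gives 0.41 mL/min. Going by the values given here, compound 1 `COc1ccc(S(=O)(=O)c2cnc3cc(F)ccc3c2-c2cccc(F)c2)cc1Cl` gives 2.08 mL/min in this assay, and the only measured step, a 5.1-fold lower number from compound 1 to compound 2 (0.71 log units; beyond the scatter), separates them. Compound 3 `COc1ccc(S(=O)(=O)c2cnc3cc(F)ccc3c2-c2cccc(F)c2)cc1` differs from compound 2 by 4-methoxyphenyl in place of 3,5-dichlorophenyl on a sulfonyl sulfur. This largely reverses the change seen in that step, so a rise beyond the scatter is expected, because a 5.1-fold lower number from compound 1 to compound 2 (0.71 log units; beyond the scatter) ran the other way. Compound 3 is therefore expected to give about 2.5 mL/min, within 1 mL/min to 6 mL/min. That estimate amounts to an expected step of a 6.1-fold higher number from compound 2 to compound 3 (0.79 log units; beyond the scatter).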

Compound 3, intrinsic clearance in a liver preparation (reported as CLH), per the amount of preparation that the assay uses: 2.94 mL/min
The estimate for compound 3 lay 1.2-fold (0.07 log units) below the measured number, and the stated range covers the measured number.
By their numbers in this assay, from the lowest: compound 2; then compounds 1 and 3 (each within the scatter of the next).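

With 4-methoxyphenyl in place of 3,5-dichlorophenyl on the sulfonyl sulfur, this assay shows a 7.2-fold higher number from compound 2 to compound 3 (0.86 log units; beyond the scatter). Hydrogen in place of chloro on an aromatic carbon gives a 1.4-fold higher number from compound 1 to compound 3 (0.15 log units; within the scatter), so with the methoxy group present, that chloro makes no clear difference. The slower removal among these compounds therefore belongs to compound 2 alone, with its 3,5-dichlorophenyl group.

No measurement shown here explains this difference. Still open, on these data alone, are whether a single chloro without methoxy would keep the low number, and how an amine or a carboxylic acid on this phenyl ring would behave.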